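This account rests on a few compounds, and the source may have more. Where it says the series, first, only, none or still open, it means among the compounds named here.

Three compounds share one core and differ only in the group attached to one aromatic carbon. Compound 1 `Cc1ccncc1-c1ccc2[nH]c(=O)nc(-c3ccccc3)c2c1` carries a 4-methylpyridin-3-yl group there. In an ADME assay on L6 cells (Rattus norvegicus) for cytotoxicity, read by fluorescence and resazurin assay, with a stated time of 72 h (a lower number here means that less compound is needed, a higher number that more compound is needed for the effect), compound 1 gives > 50000 nM, which is a limit of the assay rather than a number. Compound 2 `O=c1nc(-c2ccccc2)c2cc(-c3cc[nH]n3)ccc2[nH]1` carries a 1H-pyrazol-3-yl group instead. In this assay compound 2 gives > 50000 nM, again a limit. Compound 3 `Cn1cc(-c2ccc3[nH]c(=O)nc(-c4ccccc4)c3c2)cn1` carries a 1-methyl-1H-pyrazol-4-yl group. In this assay compound 3 gives > 50000 nM, also a limit. Compound 3 thus stands exactly where every measured compound stands, namely at the limit of > 50000 nM in this assay, at which 3 of the 3 values shown sit. The steps a step that the two limits leave unreadable from compound 1 to compound 2, a step that the two limits leave unreadable from compound 1 to compound 3 and a step that the two limits leave unreadable from compound 2 to compound 3 cannot be read from two limits; each could be small or large.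

Compound 4 `CN1CCN(c2ccc3[nH]c(=O)nc(-c4ccccc4)c3c2)CC1` is not yet measured. It differs from compound 3 by 4-methylpiperazin-1-yl in place of 1-methyl-1H-pyrazol-4-yl on an aromatic carbon. Going by the values given here, none of the measured steps has a readable size, so they give no direction for this change; they show only that three different groups at this position all left the compound at the limit. The expected step is a step that the limit leaves unreadable from compound 3 to compound 4, that is, no change readable beyond the scatter. Compound 4 is accordingly estimated to give about 80000 nM, with a range from 30000 nM to 300000 nM, and most probably only a limit once more.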

Compound 4, half-maximal effective concentration: > 50000 nM
Compound 4: only a limit was reported; the forecaster's own chance of this, stated with the estimate: 85%; the middle value is on the limit's open side.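

In this assay compound 4 gives > 50000 nM, again a limit of the assay. Going by these compounds alone, its steps from compound 1, compound 2 and compound 3 therefore cannot be read, so no new step emerges. The compounds shown leave open what concentration of any of them would produce the effect in this assay, and whether any group at this position would give a measurable value.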